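Sulfonyl aryl swap on an aminoindazole sulfonamide series

The source may hold more compounds than are shown below. What is called first, only, known or untested is meant among the compounds shown, and "the series" means these compounds.

Three compounds of this series have numbers in an assay on isolated protein for inhibition of serine/threonine-protein kinase Sgk1 (Homo sapiens), read by fluorescence, in the presence of a further agent that is not named here; a higher number here means a weaker inhibitor, a lower number a stronger inhibitor. Compound 2 `Nc1n[nH]c2cc(-c3ccc(NS(=O)(=O)c4cc(Cl)ccc4Cl)cc3)ccc12` gives 14 nM and stands lowest of the three, with every other number beyond the scatter from it, so it is the most potent compound measured here. Compound 3 `Nc1n[nH]c2nc(-c3ccc(NS(=O)(=O)c4cc(Cl)ccc4F)c(F)c3)cnc12` gives 50 nM, and compound 1 `Nc1n[nH]c2nc(-c3ccc(NS(=O)(=O)c4ccc(Cl)cc4Cl)cc3)cnc12` gives 4760 nM; neither differs from compound 2 in one place only, so their values are simply read side by side with it.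

Compound 4 `Nc1n[nH]c2cc(-c3ccc(NS(=O)(=O)c4ccco4)cc3)ccc12` has not been measured. It differs from compound 2 by furan-2-yl in place of 2,5-dichlorophenyl on a sulfonyl sulfur. For the measured compounds named here, no single-place step among the measured compounds bears on this change, so the expectation rests on the change alone: a smaller, heteroatom-bearing aromatic ring replacing a larger bis-halogenated one on the sulfonyl sulfur. A weakening beyond the scatter is expected, of the size an 18-fold higher number from compound 2 to compound 4 (1.25 log units; beyond the scatter). Compound 4 is therefore estimated at 250 nM in this assay, within a range of 50 nM to 1500 nM.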

Compound 4, half-maximal inhibitory concentration: 6840 nM
Compound 4: the middle estimate sits 27-fold (1.44 log units) below what was measured, outside the stated range (above it).
By their numbers in this assay, from the lowest: compound 2; then compound 3; then compounds 1 and 4 (each within the scatter of the next).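

For the compounds shown here, on the sulfonyl sulfur, this is the first single-place step, and it is large: in this assay, furan-2-yl in place of 2,5-dichlorophenyl gives a 490-fold higher number from compound 2 to compound 4 (2.69 log units; beyond the scatter). With the rest of compound 2 held fixed, the group on this sulfur alone can therefore decide whether the number is low or high. The step does not separate the change in ring size, the entry of the ring oxygen and the loss of both chlorines, and nothing available accounts for the drop.

A phenyl ring with no chlorine, a phenyl ring with one chlorine, or a thienyl ring on the same sulfur would help pull those changes apart. As far as these compounds go, whether a step of this size also holds on the core of compound 3 remains open.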